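Oxabicyclic Amide Acids: Piperazine Nitrogen Substituent Swap

The source may hold more compounds than are shown below. What is called first, only, known or untested is meant among the compounds shown, and "the series" means these compounds.

Measured so far:
compound 1 `O=C(Nc1ccc(S(=O)(=O)N2CCOCC2)cc1)C1C(C(=O)O)[C@H]2CC[C@@H]1O2`: 24200 nM
compound 2 `O=C(Nc1ccc(S(=O)(=O)N2CCN(c3ccc(F)cc3)CC2)cc1)C1C(C(=O)O)[C@H]2CC[C@@H]1O2`: 18400 nM

Both compounds carry the same oxabicyclic acid amide core and differ only in the sulfonamide amine. In a functional assay on A549 cells (Homo sapiens) for cytotoxicity, read by MTT assay, with a stated time of 48 h (on this read-out higher numbers stand for weaker inhibition and lower numbers for stronger inhibition), compound 1 gives 24200 nM and compound 2 gives 18400 nM. Compound 2 stands within the scatter of compound 1; on this read-out the two cannot be told apart, and no ordering between them is claimed.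

Compound 3 `CCN1CCN(S(=O)(=O)c2ccc(NC(=O)C3C(C(=O)O)[C@H]4CC[C@@H]3O4)cc2)CC1` is not yet measured. Its change from compound 2 is ethyl in place of 4-fluorophenyl on an amine nitrogen in a ring. For the measured compounds named here, no comparable step between measured compounds is available, so the size of the effect is not anchored. Given that compound 1 and compound 2 sit close together in this assay, no step beyond the scatter is expected; a small move toward a higher number is the working guess. Compound 3 is expected near 25000 nM, between 10000 nM and 60000 nM, which corresponds to an estimated 1.4-fold higher number from compound 2 to compound 3 (0.13 log units; within the scatter).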

Compound 3, half-maximal inhibitory concentration in the A549 assay: 28400 nM
Compound 3: middle estimate off by 1.1-fold (0.06 log units), on the low side; measured number inside the range.
By their numbers in the A549 assay, from the lowest: compounds 2, 1 and 3 (each within the scatter of the next).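

In the A549 assay, an aromatic ring and a short alkyl group on the amine nitrogen in the ring cannot be told apart, with a 1.5-fold higher number from compound 2 to compound 3 (0.19 log units; within the scatter), and exchanging the whole sulfonamide amine gives the same reading, with a 1.2-fold higher number from compound 1 to compound 3 (0.07 log units; within the scatter). In a physicochemical assay for lipophilicity (a higher number here means a more lipophilic compound, a lower number a more polar compound), compound 2 gives 0.6 and compound 3 gives 0.4, two values within the scatter of each other. Nothing at hand accounts for the flat cytotoxicity numbers at this position.

As far as these compounds go, whether a longer chain, an acetyl group or a plain hydrogen on that ring nitrogen would give a step beyond the scatter stays open. From the compounds shown here alone, the carboxylic acid of the shared core is the same in all three compounds, so the effect of a methyl ester or a primary amide in its place also remains open.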